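From benzyl to phenylsulfonyl on an amide-type nitrogen

The source may hold more compounds than are shown below. What is called first, only, known or untested is meant among the compounds shown, and "the series" means these compounds.

Compound 1 `CC(C)=CCC/C(C)=C/CC/C(C)=C/CC[C@]1(C)CCc2cc(OC(=O)NS(=O)(=O)c3ccc(C)cc3)cc(C)c2O1` gives 6600 nM
Compound 2 `CC(C)=CCC/C(C)=C/CC/C(C)=C/CC[C@]1(C)CCc2cc(OC(=O)NS(=O)(=O)c3ccc(Cl)cc3)c(C)c(C)c2O1` gives > 10000 nM as a limit
Compound 3 `CC(C)=CCC/C(C)=C/CC/C(C)=C/CC[C@]1(C)CCc2cc(OC(=O)NCc3ccccc3)cc(C)c2O1` gives > 10000 nM as a limit

In a functional assay on MDA-MB-231 cells (Homo sapiens) for antiproliferative activity, read by MTT assay, with a stated time of 96 h (a lower number here means a stronger inhibitor, a higher number a weaker inhibitor), compound 3 has no number, only the limit of > 10000 nM in this assay, at which 2 of the 3 values shown sit, as its place. Compound 4 `CC(C)=CCC/C(C)=C/CC/C(C)=C/CC[C@]1(C)CCc2cc(OC(=O)NS(=O)(=O)c3ccccc3)cc(C)c2O1` has not been measured and carries phenylsulfonyl in place of benzyl on an amide-type nitrogen as its change. Going by the values given here, the one measured step that bears on this runs the opposite way, with benzyl in place of (4-methylphenyl)sulfonyl: an at least 1.5-fold higher number from compound 1 to compound 3 (0.18 log units; that floor lies within the scatter) is all it shows. Compound 1, with its sulfonyl group, gives 6600 nM and so a modest move to a lower number is expected. The expected size is an at least 1.2-fold lower number from compound 3 to compound 4 (0.09 log units; that floor lies within the scatter) and it may stay within the scatter. Compound 4 is estimated at 8000 nM with an expected range of 3500 nM to 18000 nM.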

Compound 4, half-maximal inhibitory concentration: > 10000 nM
Compound 4: a limit, no number; the forecaster's own chance of this, stated with the estimate: 35%; at least 1.2-fold (0.09 log units) between middle value and limit.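

In this assay compound 4 gives only a limit, so phenylsulfonyl on the amide-type nitrogen does not by itself yield a measurable number: the limit of > 10000 nM in this assay, at which 3 of the 4 values shown sit. The step between compound 3 and compound 4 cannot be read, with a limit on both sides. Hydrogen in place of methyl on an aromatic carbon gives an at least 1.5-fold higher number from compound 1 to compound 4 (0.18 log units; that floor lies within the scatter), a floor too small to show that this methyl matters.

As far as these compounds go, whether a methoxy or ethyl group in place of that methyl would give a lower number stays open. So does how far compound 3 and compound 4 lie past their limits.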